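Removing the phenylpiperazine from compound 3

The source may hold more compounds than are shown below. What is called first, only, known or untested is meant among the compounds shown, and "the series" means these compounds.

Measured so far in a functional assay on the whole organism for antagonist activity, with Mus musculus as the target; on this read-out lower numbers stand for an effect already at smaller amounts and higher numbers for an effect only at larger amounts of compound
compound 1 (`CC(NC(=O)CN)C(=O)N(C)c1ccc(Cl)cc1C(=O)c1ccccc1Cl`) gives 0.47 mg/kg
compound 2 (`CN(C(=O)CNC(=O)c1ccccc1)c1ccc(Cl)cc1C(=O)c1ccccc1Cl`) gives 2.9 mg/kg
compound 3 (`CN(C(=O)CNC(=O)CN1CCN(c2ccccc2)CC1)c1ccc(Cl)cc1C(=O)c1ccccc1Cl`) gives 75 mg/kg

Compound 3 has the highest of the three numbers in this assay, with compound 1 and compound 2 both lying beyond the scatter below it. The next change leads to compound 4 (`CN(C)CC(=O)NCC(=O)N(C)c1ccc(Cl)cc1C(=O)c1ccccc1Cl`) and puts dimethylamino in place of 4-phenylpiperazin-1-yl on a saturated chain carbon bound to a carbonyl carbon . Among the compounds with values here, no measured step makes this exchange. The only one available, a 6.2-fold higher number from compound 1 to compound 2 (0.79 log units; beyond the scatter), is modest and involves different groups, so it bears only indirectly, showing that a change in this part of the structure can move the number beyond the scatter. Neither compound 1 nor compound 2 carries the 4-phenylpiperazin-1-yl group, and compound 2 at 2.9 mg/kg and compound 1 at 0.47 mg/kg both sit far lower. A large move to a lower number is therefore expected, an estimated 15-fold lower number from compound 3 to compound 4 (1.18 log units; beyond the scatter), though on very thin evidence. The estimate for compound 4 is 5 mg/kg, with an expected range from 1 mg/kg to 25 mg/kg.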

Compound 4, dose for half-maximal effect: 2.6 mg/kg
Compound 4: middle estimate off by 1.9-fold (0.28 log units), on the high side, and the stated range covers the measured number.
By their numbers in this assay, from the lowest: compound 1; then compounds 4 and 2 (each within the scatter of the next); then compound 3.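

In this assay, a 29-fold lower number from compound 3 to compound 4 (1.46 log units; beyond the scatter) on exchanging 4-phenylpiperazin-1-yl for dimethylamino, so the high number of compound 3 goes with that group at this saturated chain carbon bound to a carbonyl carbon. At the neighbouring level of the side chain, a 1.1-fold lower number from compound 2 to compound 4 (0.05 log units; within the scatter), so this assay does not separate (dimethylamino)methyl from phenyl on a carbonyl carbon. Compound 1 stays apart from both, with a 5.5-fold higher number from compound 1 to compound 4 (0.74 log units; beyond the scatter), a modest step for the exchange of the whole 1-(((aminomethyl)carbonyl)amino)ethyl portion.

No measurement here gives a reason for the size of the large step.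

Going by these compounds, it remains open whether a morpholin-4-yl group or an unsubstituted piperazin-1-yl group at this carbon would give a number near that of compound 4 or near that of compound 3, which would show whether the phenyl ring or the six-membered non-aromatic ring goes with the high number.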